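Swapping a benzyl for a 4-hydroxyphenyl on a ring nitrogen

The compounds below may be only part of what the source reports. "The series", "measured", "known", "first", "only" and "open" are said of these compounds alone.

Compound 1 `Cc1cc2c(c(=O)[nH]1)C(=O)O/C2=C\c1ccc(CO)n1Cc1ccccc1`: 51100 nM
Compound 2 `CC(C)c1ccc(/C=C2\C(=O)Nc3cc(Cl)ccc32)cc1`: 65000 nM
Compound 3 `COc1ccc([C@@H]2N[C@@H](CO)[C@H](O)[C@H]2O)cc1O`: 41000 nM

These three compounds were tested in an assay on kidney for inhibition of tissue alpha-L-fucosidase (Bos taurus), read by spectrophotometry, with a stated time of 10 min; on this read-out lower numbers stand for stronger inhibition and higher numbers for weaker inhibition. Compound 1 gives 51100 nM, compound 2 gives 65000 nM and compound 3 gives 41000 nM. Compound 1 has the second highest of the three numbers, but its gaps to compound 3 on one side and compound 2 on the other both lie within the usual scatter, so none of the three can be called stronger or weaker than another.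

Compound 4 `Cc1cc2c(c(=O)[nH]1)C(=O)O/C2=C\c1ccc(CO)n1-c1ccc(O)cc1` has not been measured. It differs from compound 1 in one place: 4-hydroxyphenyl in place of benzyl on an aromatic nitrogen. Among the compounds with values here, no pair of measured compounds shows what such a change does in this assay, so there is no step to lean on. The change is expected to be small, and the step from the number of compound 1 is estimated as a 1.1-fold lower number from compound 1 to compound 4 (0.06 log units; within the scatter), which would sit within the scatter. Compound 4 is therefore expected to give about 45000 nM, most likely between 15000 nM and 150000 nM.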

Compound 4, half-maximal inhibitory concentration: 21700 nM
The estimate for compound 4 lay 2.1-fold (0.32 log units) above the measured number, and the stated range covers the measured number.
By their numbers in this assay, from the lowest: compounds 4, 3, 1 and 2 (each within the scatter of the next, the first and the last beyond it).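

In this assay, the group on the aromatic nitrogen of the five-membered ring proves able to move the number: with 4-hydroxyphenyl in place of benzyl there is a 2.4-fold lower number from compound 1 to compound 4 (0.37 log units; beyond the scatter), a modest step. Both groups have the same count of heavy atoms and one six-membered aromatic ring, yet two things change together: the ring now sits directly on the nitrogen, and the entering group brings a hydrogen-bond donor and a hydrogen-bond acceptor. No supporting data explain the step or show which of these two changes matters.

A plain phenyl group and a 4-hydroxybenzyl group would pull the two changes apart, and neither is among the compounds shown. Also open, from the compounds shown here alone, is whether an amine or a carboxylic acid in place of the hydroxyl on this ring would give a similar number.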